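The source may hold more compounds than are shown below. What is called first, only, known or untested is meant among the compounds shown, and "the series" means these compounds.

Two compounds of the series carry a measured number. Compound 1 `CCOC(=O)CC(=O)N1CCSC1COc1ccccc1OC` gives 21 mg/kg in a functional assay on the whole organism for inhibition, with Cavia porcellus as the target; on this read-out higher numbers stand for an effect only at larger amounts of compound and lower numbers for an effect already at smaller amounts. Compound 2 `COc1ccccc1OCC1SCCN1C(=O)C[S+](C)[O-]` gives 25 mg/kg in this assay; the two numbers sit within the scatter of each other, so compound 2 stands alongside compound 1 rather than apart from it. Going by the values given here, the step of a 1.2-fold higher number from compound 1 to compound 2 (0.08 log units; within the scatter) is the only measured step, and it changes the same position as the one examined now.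

Compound 3 `COc1ccccc1OCC1SCCN1C(=O)CN` is the next compound of the series; it differs from compound 2 by one nitrogen atom in place of a group of 3 heavy atoms (1 carbon, 1 oxygen, 1 sulfur; no ring), on a saturated chain carbon bound to a carbonyl carbon. Among the compounds with values here, the one step that bears on it, a 1.2-fold higher number from compound 1 to compound 2 (0.08 log units; within the scatter), stayed within the scatter, and there is no measured example of an amino group at this position. On that basis no step beyond the scatter is expected for compound 3 in this assay, with no change at the digits printed from compound 2 to compound 3 (within the scatter) as the expected step. Compound 3 is estimated at 25 mg/kg, with a range from 10 mg/kg to 60 mg/kg.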

Compound 3, dose for half-maximal effect: 57 mg/kg
Beside the measured number, compound 3's estimate is 2.3-fold (0.36 log units) below it, and the stated range covers the measured number.
By their numbers in this assay, from the lowest: compounds 1 and 2 (each within the scatter of the next); then compound 3.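

Working notes on the position: in this assay the saturated chain carbon bound to a carbonyl carbon proved not to be indifferent to its group, since amino gives a 2.3-fold higher number from compound 2 to compound 3 (0.36 log units; beyond the scatter) and a 2.7-fold higher number from compound 1 to compound 3 (0.43 log units; beyond the scatter), whereas the earlier exchange there stayed within the scatter. Both new steps are modest and run the same way, towards an effect only at larger amounts of compound, so the two earlier groups stand together and amino stands apart from them. No measurement bears on the reason for this separation.

Open, from the compounds shown here alone, is whether a dimethylamino group or a carboxylic acid on the same carbon, or a longer chain ending in amino, would stay with compound 3 or fall with compounds 1 and 2. Also open, going by these compounds, is whether the amino step holds on any core other than the shared one.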